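The compounds below may be only part of what the source reports. "The series", "measured", "known", "first", "only" and "open" are said of these compounds alone.

Of the compounds shown here, three have been measured so far. In a functional assay on MES-SA cells (Homo sapiens) for cytotoxicity, read by luminescence and CellTiter-Glo, with a stated time of 72 h (a higher number here means a weaker inhibitor, a lower number a stronger inhibitor), compound 1 (`CC[C@H](NC(=O)[C@H](COC)NC(=O)c1cc(C)on1)C(=O)N[C@@H](CC(C)C)C(=O)[C@@]1(C)CO1`) gives 92 nM, compound 2 (`COC[C@H](NC(=O)c1cc(C)on1)C(=O)N[C@@H](CC(C)C)C(=O)N[C@@H](CC(C)C)C(=O)[C@@]1(C)CO1`) gives 45 nM and compound 3 (`COC[C@H](NC(=O)c1cc(C)on1)C(=O)N[C@@H](CC#N)C(=O)N[C@@H](CC(C)C)C(=O)[C@@]1(C)CO1`) gives 29 nM. Compound 3 thus stands clear of compound 1 but cannot be told apart from compound 2. The next compound is compound 4 (`COC[C@H](NC(=O)c1cc(C)on1)C(=O)N[C@@H](COC)C(=O)N[C@@H](CC(C)C)C(=O)[C@@]1(C)CO1`), which differs from compound 3 in one place: methoxy in place of cyano on a saturated chain carbon, two bonds along the chain from an amide-type nitrogen and a carbonyl carbon. This is methoxy in place of cyano on a saturated chain carbon, two bonds along the chain from an amide-type nitrogen and a carbonyl carbon, or, cut one bond further out, cyanomethyl to methoxymethyl.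

Three measured steps change this same place. Isopropyl in place of methyl gave a 2.0-fold lower number from compound 1 to compound 2 (0.31 log units; beyond the scatter), cyano in place of methyl gave a 3.2-fold lower number from compound 1 to compound 3 (0.50 log units; beyond the scatter), and cyano in place of isopropyl gave a 1.6-fold lower number from compound 2 to compound 3 (0.19 log units; within the scatter). None of them involves methoxy, so they indicate only the likely size of a change here. In this assay no step beyond the scatter is therefore expected, and any drift is expected toward a higher number, in the direction of compound 1 at 92 nM. The estimated step is a 1.6-fold higher number from compound 3 to compound 4 (0.19 log units; within the scatter). For compound 4 the expected value is 45 nM, with an estimated range from 18 nM to 110 nM.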

Compound 4, half-maximal inhibitory concentration: 22 nM
Compound 4: the middle estimate sits 2.0-fold (0.31 log units) above what was measured; the measured number falls inside the stated range.
By their numbers in this assay, from the lowest: compounds 4, 3 and 2 (each within the scatter of the next, the first and the last beyond it); then compound 1.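

In this assay, methoxy and cyano cannot be told apart at this position, on a saturated chain carbon, two bonds along the chain from an amide-type nitrogen and a carbonyl carbon: the exchange gives a 1.3-fold lower number from compound 3 to compound 4 (0.12 log units; within the scatter) and leaves the count of heavy atoms and of hydrogen-bond acceptors as it was. Methoxy in place of isopropyl gives a 2.0-fold lower number from compound 2 to compound 4 (0.31 log units; beyond the scatter) and so clears the scatter, which cyano in place of isopropyl did not, while methoxy in place of methyl gives a 4.2-fold lower number from compound 1 to compound 4 (0.62 log units; beyond the scatter) and adds a second group that stands clear of methyl at this place. The data offer no explanation for why methoxy and cyano read alike here, or for why methyl stands apart from both.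

The compounds shown leave open whether a longer ether chain, an amine or a carboxylic acid at this place would stay level with methoxy and cyano or move toward compound 1. They also leave open whether methoxy and cyano would still read alike on a core with a different chain elsewhere.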